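Swapping a sulfonyl substituent in a urea series

A few compounds are considered here, and "the series" means these few. Any claim that something is new, unique, unknown or untested is made for them only; others in the source may bear on it.

Compound 1 `CCN(CC)S(=O)(=O)NC(=O)Nc1c(C(C)C)cccc1C(C)C` gives 2500 nM in an assay on liver for inhibition of sterol O-acyltransferase 1 (Rattus norvegicus), using microsomes (a higher number here means a weaker inhibitor, a lower number a stronger inhibitor), the highest of the two numbers measured. Compound 2 `CC(C)c1cccc(C(C)C)c1NC(=O)NS(=O)(=O)N(Cc1ccccc1)C(C)C` gives 400 nM in this assay, a difference beyond the scatter. Compound 3 `CCCCCCOS(=O)(=O)NC(=O)Nc1c(C(C)C)cccc1C(C)C` has not been measured. It differs from compound 1 by hexyloxy in place of diethylamino on a sulfonyl sulfur. For the measured compounds named here, no measured pair shows this change, so the step from compound 1 to compound 3 is expected to be small, estimated as a 1.7-fold lower number from compound 1 to compound 3 (0.22 log units; within the scatter), leaning toward a lower number because compound 2 gives 400 nM with a different group at the same sulfur. Compound 3 is expected to give about 1500 nM, in a range from 400 nM to 6000 nM.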

Compound 3, half-maximal inhibitory concentration: 27000 nM
Compound 3: the middle estimate sits 18-fold (1.26 log units) below what was measured, and the stated range ends below it.
By their numbers in this assay, from the lowest: compound 2; then compound 1; then compound 3.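

Hexyloxy in place of diethylamino on the sulfonyl sulfur gives an 11-fold higher number from compound 1 to compound 3 (1.03 log units; beyond the scatter) in this assay and so shows that inhibition can depend strongly on the group at this position. This one swap replaces both the atom attached to sulfur and the chain, so the step cannot show which of the two matters. No measurement here accounts for the rise. As far as these compounds go, whether the oxygen link or the length of the chain goes with the higher number remains open. From the compounds shown here alone, how a shorter ethoxy group or a hexylamino group would compare at this sulfur also remains unknown.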